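Shifting the methoxy group in compound 3

This account rests on a few compounds, and the source may have more. Where it says the series, first, only, none or still open, it means among the compounds named here.

Measured in an in vitro ADME assay on microsomes from liver (Homo sapiens) for metabolic stability; on this read-out higher numbers stand for fast clearance and lower numbers for slow clearance:
- compound 1 `COc1cccc(C(=O)N2CCC(=CC(=O)N[C@@H]3CCN(Cc4ccc5cc(F)ccc5c4)C3)CC2)c1`: 500 mL/min/kg
- compound 2 `COc1ccc(O)c(C(=O)N2CCC(=CC(=O)N[C@@H]3CCN(Cc4ccc5cc(F)ccc5c4)C3)CC2)c1`: 119 mL/min/kg

Of the two measured compounds, compound 2 has the lower clearance, at 119 mL/min/kg. Compound 3 `COc1ccc(C(=O)N2CCC(=CC(=O)N[C@@H]3CCN(Cc4ccc5cc(F)ccc5c4)C3)CC2)c(O)c1` is still unmeasured and differs from it in one group: 2-hydroxy-4-methoxyphenyl in place of 2-hydroxy-5-methoxyphenyl on a carbonyl carbon. Among the compounds with values here, the only measured step nearby, a 4.2-fold lower number from compound 1 to compound 2 (0.62 log units; beyond the scatter), added the hydroxy that compound 3 keeps. Within the data shown here, no measured step shows what a 2-hydroxy-4-methoxyphenyl in place of a 2-hydroxy-5-methoxyphenyl does, so the starting expectation is no change beyond the scatter in this assay. The expected step is a 1.1-fold higher number from compound 2 to compound 3 (0.02 log units; within the scatter). The estimate for compound 3 is 125 mL/min/kg, with an expected range of 55 mL/min/kg to 290 mL/min/kg.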

Compound 3, clearance: 232 mL/min/kg
Estimate against measurement, compound 3: 1.9-fold (0.27 log units) below; the range from low to high includes it.
By their numbers in this assay, from the lowest: compounds 2 and 3 (each within the scatter of the next); then compound 1.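

In this assay, the change from 2-hydroxy-5-methoxyphenyl to 2-hydroxy-4-methoxyphenyl gives a 1.9-fold higher number from compound 2 to compound 3 (0.29 log units; within the scatter) and so does not separate these two groups on the carbonyl carbon. Replacing 3-methoxyphenyl with 2-hydroxy-4-methoxyphenyl gives a 2.2-fold lower number from compound 1 to compound 3 (0.33 log units; beyond the scatter) and shows that the lower clearance seen earlier is not confined to the 2-hydroxy-5-methoxyphenyl group. No measurement here offers an explanation for these results.

Still open, from the compounds shown here alone, is whether an amine or a carboxylic acid in place of the hydroxy would also keep clearance down, and whether the methoxy is needed at all.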